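Adding a Methoxy Group: One Step, Two Settings

The source may report more compounds than this note shows. Statements on the series, on what has been measured and on what is new or still open speak of the compounds shown alone.

Of the compounds shown here, three have been tested in a functional assay on PC-3 cells (Homo sapiens) for inhibition, read by sulforhodamine B assay, with a stated time of 48 h; a higher number here means a weaker inhibitor of growth, a lower number a stronger inhibitor of growth. Compound 1 `C=C(C)[C@@H]1CC=C(Cn2cc(COc3ccc(C4NC(=O)NC5=C4C(=O)CC(C)(C)C5)cc3)nn2)CC1` gives 24000 nM in this assay. Compound 2 `C=C(C)[C@@H]1CC=C(Cn2cc(COc3cccc(C4NC(=O)NC5=C4C(=O)CC(C)(C)C5)c3)nn2)CC1` is built from the same atoms joined differently; the difference between the two cores is not broken down here. In this assay compound 2 gives 21900 nM, which lies within the scatter of the number for compound 1, so the two cannot be told apart. Compound 3 `C=C(C)[C@@H]1CC=C(Cn2cc(COc3cc(C4NC(=O)NC5=C4C(=O)CC(C)(C)C5)ccc3OC)nn2)CC1` carries one extra group relative to compound 2: methoxy in place of hydrogen on an aromatic carbon. In this assay compound 3 gives 79900 nM, and the measured step is a 3.6-fold higher number from compound 2 to compound 3 (0.56 log units; beyond the scatter).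

The unmeasured compound 4 `C=C(C)[C@@H]1CC=C(Cn2cc(COc3ccc(C4NC(=O)NC5=C4C(=O)CC(C)(C)C5)cc3OC)nn2)CC1` stands to compound 1 as compound 3 stands to compound 2: methoxy in place of hydrogen on an aromatic carbon. This is the same kind of change, though not the same one: in compound 3 the new group sits ortho to a large group and para to a large group, whereas in compound 4 it sits ortho to a large group and meta to a large group. The change appears twice among these compounds, and only one instance has a measurement.

For the measured compounds named here, the step from compound 1 to compound 4 in this assay is expected to be a 3.0-fold higher number from compound 1 to compound 4 (0.48 log units; beyond the scatter), set beside the earlier step of a 3.6-fold higher number from compound 2 to compound 3 (0.56 log units; beyond the scatter), because a 3.6-fold higher number from compound 2 to compound 3 (0.56 log units; beyond the scatter) is the only guide available and the surroundings differ slightly. Compound 4 is therefore estimated at about 72000 nM in this assay, with a likely range from 30000 nM to 160000 nM.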

Compound 4, concentration for total growth inhibition: > 100000 nM
Compound 4 ended at the assay's limit; the forecaster's own chance of this, stated with the estimate: 10%; middle value at least 1.3-fold (0.14 log units) from the limit.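

In this assay compound 4 reads > 100000 nM, which is a limit of the assay and not a number. Placing methoxy on the aromatic ring of the core of compound 1 gives an at least 4.1-fold higher number from compound 1 to compound 4 (0.61 log units; beyond the scatter), so on both cores shown the same kind of change goes with a higher number, meaning weaker growth inhibition, and each step lies beyond the usual scatter: the same change on two cores in this assay, a 3.6-fold higher number (0.56 log units; beyond the scatter) from compound 2 to compound 3 and an at least 4.1-fold higher number (0.61 log units; beyond the scatter) from compound 1 to compound 4; the limit leaves it open whether they differ. For the compounds shown here, this is agreement in direction across only two cores, with the methoxy ortho to a large group and meta to a large group in compound 4; it does not show how large the step on the core of compound 1 really is, or whether the change carries over with the same size, since that reading stops at the limit: the limit of > 100000 nM in this assay, at which 1 of the 4 values shown sits.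

The compounds shown leave open whether the higher number is tied to methoxy itself or would also appear with a different group on the same aromatic carbon, such as hydroxy, fluorine, an amine or the longer ethoxy chain. They also leave open how the change would behave on any core beyond these two, and a value for compound 4 below the limit would be needed to compare the two steps in size.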